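Swapping the benzyl substituent toward the tolerance ceiling

This account rests on a few compounds, and the source may have more. Where it says the series, first, only, none or still open, it means among the compounds named here.

Compound 2 `Cc1cccc(CNCc2cc(=O)c3c(O)c(O)ccc3o2)c1` comes from compound 1 `O=c1cc(CNCc2ccccc2I)oc2ccc(O)c(O)c12` by a change on the benzyl group. In an ADME assay on Huh-7 cells (Homo sapiens) for cytotoxicity (a lower number here means that less compound is tolerated, a higher number that more compound is tolerated), compound 1 gives 87300 nM. In this assay, going by these compounds, compound 2 reaches only a limit, > 100000 nM, so its true number is unknown, as noted in the limit of > 100000 nM in this assay, at which 1 of the 2 values shown sits. The step of an at least 1.1-fold higher number from compound 1 to compound 2 (0.05 log units; that floor lies within the scatter) stays within scatter. Compound 3 `O=c1cc(CNCc2ccc(Cl)cc2)oc2ccc(O)c(O)c12` differs by 4-chlorophenyl in place of 3-methylphenyl on a saturated chain carbon bound to an amine nitrogen. Both measured values sit near the top of this assay, so the step is expected to be a number no higher from compound 2 to compound 3 (the limit leaves the size open). Compound 3 is estimated at 100000 nM, between 50000 nM and 200000 nM, quite possibly again only a limit.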

Compound 3, half-maximal cytotoxic concentration: > 100000 nM
Compound 3 was reported as a limit; the forecaster's own chance of this, stated with the estimate: 55%; the middle value lies on the limit itself.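

In this assay compound 3 is reported only as a limit, > 100000 nM. Putting 4-chlorophenyl in place of 2-iodophenyl gives an at least 1.1-fold higher number from compound 1 to compound 3 (0.05 log units; that floor lies within the scatter), so this change shows no real shift, and a chlorine-bearing ring joins the iodine-bearing and methyl-bearing rings in being well tolerated. The step from compound 2 to compound 3 cannot be read, because both stand at the same limit: the limit of > 100000 nM in this assay, at which 2 of the 3 values shown sit. Going by these compounds, how far above that limit compound 2 and compound 3 truly lie stays open. Also open, on these data alone, is whether a carboxylic acid or an amine in this place would bring the number into the readable range.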